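The compounds below may be only part of what the source reports. "The series", "measured", "known", "first", "only" and "open" are said of these compounds alone.

Working notes on the series. The shared core of compound 1 `COc1ccc(-c2cc(/C=C/C(=O)c3ccc(N)cc3)[nH]n2)cc1`, compound 2 `COc1cc(-c2cc(/C=C/C(=O)c3ccc(N)cc3)[nH]n2)cc(OC)c1OC` and compound 3 `COc1ccc(C(=O)/C=C/c2cc(-c3cc(OC)c(OC)c(OC)c3)n[nH]2)cc1OC` has been tested in a functional assay on KM12 cells (Homo sapiens) for cytotoxicity, read by sulforhodamine B assay, with a stated time of 48 h, tested at 0.01 uM; a lower number here means a stronger effect, a higher number a weaker effect of the compound at the concentration tested. Compound 1 gives 96%, compound 2 gives 102% and compound 3 gives 97%; both other numbers lie within the scatter of the number for compound 2, so no order among the three can be read from them. Among the compounds with values here, the only single-point step measured so far is a number 5 percentage points lower from compound 2 to compound 3 (within the scatter). Compound 4 `COc1ccc(-c2cc(/C=C/C(=O)c3ccc(N)cc3)[nH]n2)cc1OC` differs from compound 2 by hydrogen in place of methoxy on an aromatic carbon. Within the data shown here, no measured step removes a methoxy group, so the change has no direct precedent here; the one step known did not move the read-out beyond the scatter. Compound 4 is therefore expected to show a number 4 percentage points lower from compound 2 to compound 4 (within the scatter), with an estimate of 98% in a range of 88% to 108%.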

Compound 4, a percentage reported as activity, at one concentration (the size of the read-out at that concentration, not a potency): 102%
For compound 4 the middle estimate is 4 percentage points below the measured one, within the range that was stated.
By their numbers in this assay, from the lowest: compounds 1, 3, 2 and 4 (each within the scatter of the next).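

Removing the methoxy group from this aromatic carbon leaves the read-out in this assay unmoved, with no change at the digits printed from compound 2 to compound 4 (within the scatter). The reverse kind of change, adding a methoxy group on an aromatic carbon, gives a number 6 percentage points higher from compound 1 to compound 4 (within the scatter), so neither change at this part of the aromatic ring separates these compounds at the concentration tested. No measured evidence bears on this result. Open, from the compounds shown here alone, is whether a hydroxy group or an amine on this aromatic carbon would shift the read-out beyond the scatter. Also open, going by these compounds, is whether these methoxy changes would separate the compounds at other concentrations.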